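A few compounds are considered here, and "the series" means these few. Any claim that something is new, unique, unknown or untested is made for them only; others in the source may bear on it.

Working notes on the series. Of the compounds shown here, two have been measured in a functional assay on NCI-H1299 cells (Homo sapiens) for inhibition, read by CCK-8 assay, with a stated time of 72 h, tested at 1 uM; a higher number here means a stronger effect of the compound at the concentration tested, a lower number a weaker effect. Compound 1 `CN(C)C(=O)c1cc2cnc(Nc3ccc(C(=O)NCCCCCCN=C=S)cc3)nc2n1C1CCCC1` gives 49.4% in this assay. Compound 2 `CN(C)C(=O)c1cc2cnc(Nc3ccc(NC(=O)CCCCN=C=S)cc3)nc2n1C1CCCC1` gives 58.6% in this assay. Going by the values given here, the step of a number 9.2 percentage points higher from compound 1 to compound 2 (within the scatter) is the only measured step so far, and it does not separate the two compounds; compound 2 and compound 1 sit within the scatter of each other, so neither can be called the stronger.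

Compound 3 `CN(C)C(=O)c1cc2cnc(Nc3ccc(NC(=O)CCCCCCN=C=S)cc3)nc2n1C1CCCC1` has not yet been measured. It differs from compound 2 by a group of 5 heavy atoms (3 carbon, 1 nitrogen, 1 sulfur; no ring) in place of a group of 3 heavy atoms (1 carbon, 1 nitrogen, 1 sulfur; no ring), on a saturated chain carbon, four bonds along the chain from a carbonyl carbon. Among the compounds with values here, the one measured step, which also involved a longer chain together with a reversed amide, stayed within the scatter, and no measured pair isolates a chain-length change alone. On that basis the chain lengthening in compound 3 is expected to leave this assay about where compound 2 stands, with the expected step of a number 2.6 percentage points lower from compound 2 to compound 3 (within the scatter) not beyond the scatter. Compound 3 is therefore estimated at 56% in this assay, with a range from 42% to 70%, the width reflecting the thin basis.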

Compound 3, a percentage reported as inhibition, at one concentration (the size of the read-out at that concentration, not a potency): 50.9%
Compound 3: middle estimate off by 5.1 percentage points, on the high side; low and high end bracket the measured number.
By their numbers in this assay, from the lowest: compounds 1, 3 and 2 (each within the scatter of the next).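

In this assay, going by these compounds alone, this is the first comparison that changes chain length alone, on a saturated chain carbon, four bonds along the chain from a carbonyl carbon, with the amide direction held fixed: the result is a number 7.7 percentage points lower from compound 2 to compound 3 (within the scatter) and so the added length does not separate the pair. The other new comparison holds the count at 12 heavy atoms on an aromatic carbon and changes the arrangement of the group, including the amide direction; it gives a number 1.5 percentage points higher from compound 1 to compound 3 (within the scatter) and so shows that this rearrangement, at equal group size, does not separate its pair either. No supporting data bear on these results.

Going by these compounds, whether a longer chain, or a terminal amine or carboxylic acid at the chain end, would produce a step beyond the scatter remains open. On these data alone, all three compounds are read at a single concentration, so their relative potency also remains open, and with it any difference that this read-out cannot show.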